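From 3-methoxyphenyl to 4-methoxyphenyl on a shared core

The source may report more compounds than this note shows. Statements on the series, on what has been measured and on what is new or still open speak of the compounds shown alone.

In a functional assay on U-937 cells (Homo sapiens) for antiproliferative activity, read by CCK-8 assay, with a stated time of 72 h (on this read-out lower numbers stand for stronger inhibition and higher numbers for weaker inhibition), compound 1 (`Cc1cc(Nc2cc(N3CCN(C)CC3)nc(Nc3ccc(Cl)cc3)n2)n[nH]1`), carrying 4-chlorophenyl, gives 55.4 nM. For the measured compounds named here, compound 2 (`COc1cccc(Nc2nc(Nc3cc(C)[nH]n3)cc(N3CCN(C)CC3)n2)c1`), carrying 3-methoxyphenyl, gives 126 nM, the higher of the two numbers so far. Compound 3 (`COc1ccc(Nc2nc(Nc3cc(C)[nH]n3)cc(N3CCN(C)CC3)n2)cc1`) has not yet been measured. It has 4-methoxyphenyl in place of 3-methoxyphenyl on a nitrogen on an aromatic ring. Going by the values given here, one measured step bears on this place, the modest 2.3-fold higher number from compound 1 to compound 2 (0.36 log units; beyond the scatter). That step exchanges a 4-chlorophenyl for a 3-methoxyphenyl, so it gives a scale for changes here but does not isolate the change now in question. A shift smaller than that step is therefore expected, leaning slightly toward a lower number and probably not beyond the scatter. The expected change is a 1.3-fold lower number from compound 2 to compound 3 (0.12 log units; within the scatter). Compound 3 is estimated at 95 nM, with an expected range of 40 nM to 230 nM.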

Compound 3, half-maximal inhibitory concentration: 92.3 nM
Beside the measured number, compound 3's estimate is 1.0-fold (0.01 log units) above it, and the stated range covers the measured number.
By their numbers in this assay, from the lowest: compounds 1, 3 and 2 (each within the scatter of the next, the first and the last beyond it).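

In this assay, exchanging 3-methoxyphenyl for 4-methoxyphenyl gives a 1.4-fold lower number from compound 2 to compound 3 (0.14 log units; within the scatter), so this change of place alone does not separate the two methoxy compounds. Methoxy in place of chloro on an aromatic carbon, now read without that change of place, gives a 1.7-fold higher number from compound 1 to compound 3 (0.22 log units; within the scatter), which leaves the step that changes both group and place, a 2.3-fold higher number from compound 1 to compound 2 (0.36 log units; beyond the scatter), as the only one of the three beyond the scatter. No measurement offered here accounts for any of these steps.

The compounds shown carry only chloro and methoxy on this phenyl ring, so it stays open how an amine, a carboxylic acid or a longer chain such as butoxy would read there. On these data alone, it also stays open whether these steps would hold in cells other than the ones tested here.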